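The compounds below may be only part of what the source reports. "The series", "measured", "known", "first", "only" and "open" are said of these compounds alone.

Compound 1 `COc1cc(CSc2cc(Cl)c(-c3nnc(-c4ccc(Cl)cc4)s3)cc2S(=O)(=O)NC(=N)NO)cc(OC)c1OC` gives 26300 nM in a functional assay on UACC-257 cells (Homo sapiens); on this read-out lower numbers stand for stronger inhibition of growth and higher numbers for weaker inhibition of growth. Compound 2 `COc1cc(CSc2cc(Cl)c(-c3nc(-c4ccccc4)no3)cc2S(=O)(=O)NC(=N)NO)cc(OC)c1OC` gives 13200 nM in this assay. Compound 3 `COc1cc(CSc2cc(Cl)c(-c3nnc(-c4ccccc4)s3)cc2S(=O)(=O)NC(=N)NO)cc(OC)c1OC` gives 6030 nM in this assay.

Among these three, compound 3 carries the lowest number in this assay: the change a 2.2-fold lower number from compound 2 to compound 3 (0.34 log units; beyond the scatter) and the change a 4.4-fold lower number from compound 1 to compound 3 (0.64 log units; beyond the scatter) both lead to it, and both lie beyond the scatter, so compound 3 stands as the strongest grower inhibitor of the set.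

Compound 4 `COc1cc(CSc2cc(Cl)c(-c3nc(-c4ccc(Cl)cc4)no3)cc2S(=O)(=O)NC(=N)NO)cc(OC)c1OC` is reached from compound 3 by 3-(4-chlorophenyl)-1,2,4-oxadiazol-5-yl in place of 5-phenyl-1,3,4-thiadiazol-2-yl on an aromatic carbon. Among the measured compounds shown here, two measured steps bear on this change. The oxadiazole-for-thiadiazole exchange was seen as a 2.2-fold lower number from compound 2 to compound 3 (0.34 log units; beyond the scatter), read here in reverse; the chloro on the phenyl was seen as a 4.4-fold lower number from compound 1 to compound 3 (0.64 log units; beyond the scatter), also read in reverse. Compound 4 unites both features that were removed on the way to compound 3, so in this assay a rise in the number is expected, larger than either single step, roughly the two combined, though combination need not be fully additive. The step is therefore expected to be a 7.5-fold higher number from compound 3 to compound 4 (0.87 log units; beyond the scatter). Compound 4 is expected to give 45000 nM in this assay, within a range of 15000 nM to 120000 nM.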

Compound 4, concentration for 50% growth inhibition: 9330 nM
Compound 4: the middle estimate sits 4.8-fold (0.68 log units) above what was measured; the measured number lies below the stated range.
By their numbers in this assay, from the lowest: compounds 3, 4, 2 and 1 (each within the scatter of the next, the first and the last beyond it).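

In this assay, chloro in place of hydrogen on the 3-phenyl-1,2,4-oxadiazol-5-yl group gives a 1.4-fold lower number from compound 2 to compound 4 (0.15 log units; within the scatter), so the loss seen when the same chloro sits on the 5-phenyl-1,3,4-thiadiazol-2-yl group does not carry over to the oxadiazole, and the effect of this chloro depends on the five-membered aromatic ring that carries its phenyl: the same change on two cores in this assay, a 4.4-fold lower number (0.64 log units; beyond the scatter) from compound 1 to compound 3 and a 1.4-fold higher number (0.15 log units; within the scatter) from compound 4 to compound 2, 6.2-fold (0.79 log units) apart, beyond the scatter of two such steps

With the chloro kept on both sides, the exchange of the thiadiazole for the oxadiazole gives a 2.8-fold lower number from compound 1 to compound 4 (0.45 log units; beyond the scatter), a gain that the unsubstituted pair had pointed the other way. Exchanging ring and adding chloro together gives a 1.5-fold higher number from compound 3 to compound 4 (0.19 log units; within the scatter), so compound 4 cannot be told apart from compound 3 on this read-out.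

The compounds shown carry only hydrogen or chloro on this phenyl, so it stays open how a methoxy group or an amine in the place of that chloro would behave on either five-membered ring. They also do not tell why the chloro counts on one ring and not on the other.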